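The source may report more compounds than this note shows. Statements on the series, on what has been measured and on what is new or still open speak of the compounds shown alone.

Measured compounds:
compound 1 `COc1cc(C)cc(-c2c(-c3ccnc(-c4ccc(C(C)=O)cc4)c3)cnn2CC#N)c1` > 100000 nM
compound 2 `COc1cc(C)cc(-c2nn(CC#N)cc2-c2ccnc(-c3ccc(N(C)C)cc3)c2)c1` 3240 nM
compound 3 `Cc1cc(O)cc(-c2nn(CC#N)cc2-c2ccnc(-c3ccc(N(C)C)cc3)c2)c1` 68100 nM

Compound 1 `COc1cc(C)cc(-c2c(-c3ccnc(-c4ccc(C(C)=O)cc4)c3)cnn2CC#N)c1` returns only a limit in a functional assay on NCI-H522 cells (Homo sapiens) for inhibition, read by sulforhodamine B assay, with a stated time of 48 h (on this read-out lower numbers stand for higher toxicity in this test and higher numbers for lower toxicity in this test), > 100000 nM, so its standing among the three is known only as a boundary (the limit of > 100000 nM in this assay, at which 1 of the 3 values shown sits). Compound 2 `COc1cc(C)cc(-c2nn(CC#N)cc2-c2ccnc(-c3ccc(N(C)C)cc3)c2)c1` gives 3240 nM in this assay. For the measured compounds named here, compound 3 `Cc1cc(O)cc(-c2nn(CC#N)cc2-c2ccnc(-c3ccc(N(C)C)cc3)c2)c1` gives 68100 nM in this assay; the single measured step, a 21-fold higher number from compound 2 to compound 3 (1.32 log units; beyond the scatter), concerns the phenol end and does not touch the aryl group changed here.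

Compound 4 `COc1cc(C)cc(-c2c(-c3ccnc(-c4ccc(N(C)C)cc4)c3)cnn2CC#N)c1` follows from compound 1 by dimethylamino in place of acetyl on an aromatic carbon. Going by the values given here, no measured pair carries this same change, so no step bears on it directly. Among the compounds with values here, compound 2 and compound 4 carry the same two aryl groups on the shared core with the core joined differently; compound 2 is the only measured dimethylamino analogue and sits far from the limit of compound 1. The step of an at least 5.0-fold lower number from compound 1 to compound 4 (0.69 log units; beyond the scatter) is therefore expected to move toward a measurable number, with wide uncertainty. Compound 4 is estimated at 20000 nM in this assay, with a range from 3000 nM to 100000 nM.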

Compound 4, concentration lethal to 50% of the cells: 3220 nM
Compound 4: middle estimate off by 6.2-fold (0.79 log units), on the high side; the measured number falls inside the stated range.
By their numbers in this assay, from the lowest: compounds 4 and 2 (each within the scatter of the next); then compound 3. At a limit, above all of these: compound 1.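

In this assay, dimethylamino in place of acetyl on an aromatic carbon gives an at least 31-fold lower number from compound 1 to compound 4 (1.49 log units; beyond the scatter), the first step read at this aryl group and a large one. The two groups match in heavy atoms and in hydrogen-bond acceptors, so those counts alone do not separate the two compounds here. Compound 1 stands at a limit, so this step gives only a minimum size: the limit of > 100000 nM in this assay, at which 1 of the 4 values shown sits.

Open, going by these compounds, is how narrow the demand at this place is: whether a primary amine, a morpholine or a carboxylic acid in place of dimethylamino would stay near compound 4 at 3220 nM. Also open, on these data alone, is whether acetyl on the core as joined in compound 2 would give a step of the same size.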